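The source may report more compounds than this note shows. Statements on the series, on what has been measured and on what is new or still open speak of the compounds shown alone.

Among the measured compounds shown here, in a functional assay on A549 cells (Homo sapiens) for antiproliferative activity, read by MTT assay, with a stated time of 72 h (a higher number here means a weaker inhibitor, a lower number a stronger inhibitor), compound 1 `O=C1COc2ccc(-c3cccc(NS(=O)(=O)c4ccc(F)cc4)c3)cc2N1` gives 32100 nM and stands level with the only other measured compound. That one, compound 2 `Cc1ccc(N2C(=O)COc3ccc(-c4cnc(Cl)c(NS(=O)(=O)c5ccc(F)cc5)c4)cc32)cc1`, gives 30900 nM and the two numbers lie within the scatter of each other. Both compounds are weak inhibitors here.

For the measured compounds named here, compound 3 `O=C1COc2ccc(-c3cccc(NS(=O)(=O)c4ccc(F)cc4)c3)cc2N1C1CC1` keeps the core of compound 1 and carries cyclopropyl in place of hydrogen on an amide-type nitrogen in a ring as its only change. Going by the values given here, no measured pair shows this change on its own, so the data give no direct guide to its size. The expectation therefore starts from compound 1 at 32100 nM and allows a wide margin on either side. In this assay a small step toward a lower number is expected, one likely to stay within the scatter. The estimated move a 1.6-fold lower number from compound 1 to compound 3 (0.21 log units; within the scatter) is modest in size. For compound 3 the estimated value is 20000 nM with an expected range from 6000 nM to 60000 nM around it.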

Compound 3, half-maximal inhibitory concentration: > 40000 nM
Compound 3 ended at the assay's limit; the forecaster's own chance of this, stated with the estimate: 15%; middle value at least 2.0-fold (0.30 log units) away from the limit.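

In this assay compound 3 gives > 40000 nM, which is a limit of the assay and not a number. Among the compounds shown here, the step reads an at least 1.2-fold higher number from compound 1 to compound 3 (0.09 log units; that floor lies within the scatter), so this is the first direct look at cyclopropyl in place of hydrogen on an amide-type nitrogen in a ring, and the small gain that might have been hoped for does not appear: the change gives no lower number here. How far the number rose cannot be read from a limit, so the change could be nearly neutral or clearly harmful, and the limit itself applies to only one compound so far: the limit of > 40000 nM in this assay, at which 1 of the 3 values shown sits.

Compound 2 also carries a group on this nitrogen, but it differs from compound 1 in more than one place, so it cannot show what that group does alone. The compounds shown leave open whether a smaller group such as methyl, or a longer chain ending in an amine or a carboxylic acid, would give a lower number at this nitrogen, and whether any change here could move this weak series into a clearly stronger range.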